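Oxane variation in the calcium-channel inhibitor series

This account rests on a few compounds, and the source may have more. Where it says the series, first, only, none or still open, it means among the compounds named here.

Three compounds on one shared core have numbers in an assay on HEK293 cells for inhibition of Voltage-dependent N-type calcium channel subunit alpha-1B (Homo sapiens), read by fluorescence and calcium flux, with a stated time of 5 min; a higher number here means a weaker inhibitor, a lower number a stronger inhibitor. Compound 1 `COc1ccccc1-n1nc(C2CC(C)(C)OC(C)(C)C2)cc1-c1ccnc(Cl)c1` gives 11 nM. Compound 3 `CCOc1ccc(-c2cc(C3CC(C)(C)OC(C)(C)C3)nn2-c2ccccc2OC)cn1` gives 5 nM; the single-site change between them is a 2.2-fold lower number from compound 1 to compound 3 (0.34 log units; beyond the scatter), which concerns the aryl group on the core and leaves the oxane untouched. Compound 2 `COc1ccccc1-n1nc([C@H]2C[C@@H](C)O[C@@H](C)C2)cc1-c1ccc(Cl)cc1` gives 3 nM, the lowest of the three numbers: its gap to compound 3 lies within the scatter, its gap to compound 1 beyond it. Compound 1 and compound 3 both carry a tetramethyl oxane where compound 2 carries a dimethyl oxane, but each also differs from compound 2 in the aryl group, so their values show nothing on their own about the oxane.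

Compound 4 `COc1ccccc1-n1nc([C@@H]2CCO[C@H](C(C)C)C2)cc1-c1ccc(Cl)cc1` is not yet measured. Its change from compound 2 is 2-isopropyloxan-4-yl in place of 2,6-dimethyloxan-4-yl on an aromatic carbon. Within the data shown here, no measured step touches this position; the only step available is modest and sits on the aryl group. The expected step is therefore a 1.3-fold higher number from compound 2 to compound 4 (0.12 log units; within the scatter), within the scatter and in no firm direction. Compound 4 is expected to give 4 nM in this assay, with a range from 1.5 nM to 12 nM.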

Compound 4, half-maximal inhibitory concentration: 7 nM
Compound 4: middle estimate off by 1.8-fold (0.24 log units), on the low side; the range from low to high includes it.
By their numbers in this assay, from the lowest: compounds 2, 3, 4 and 1 (each within the scatter of the next, the first and the last beyond it).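

Working notes on the oxane position: in this assay the first direct reading at this position is a 2.3-fold higher number from compound 2 to compound 4 (0.37 log units; beyond the scatter) and shows that the substituent pattern on the oxane can move the number beyond the scatter, although only modestly. The change replaces 2,6-dimethyloxan-4-yl with 2-isopropyloxan-4-yl, going from 8 heavy atoms to 9 and from 3 defined stereocentres to 2, while the count of hydrogen-bond acceptors and the absence of donors stay the same, so compound 4 at 7 nM remains an inhibitor with a single ring oxygen in this group. No measurement available bears on the reason for this step.

This single step cannot separate the effect of the isopropyl group from that of losing the second substituent or changing the defined stereochemistry, and a simple 2-methyloxan-4-yl group would be needed to divide them. Also open, from the compounds shown here alone, are the effect of a ring nitrogen amine, as in piperidin-4-yl, at this position and the reading of the tetramethyl oxane alongside the 4-chlorophenyl group.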